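The compounds below may be only part of what the source reports. "The series", "measured", "known", "first", "only" and "open" are said of these compounds alone.

Three compounds share one core and differ only in the group on a carbon with a double bond to nitrogen: compound 1 `CN(C)C(=O)C[C@H](CSc1ccccc1)Nc1c(C(=O)N/N=C/c2ccccc2F)cnc2c(C(F)(F)F)cccc12`, compound 2 `CN(C)C(=O)C[C@H](CSc1ccccc1)Nc1c(C(=O)N/N=C/c2ccc(F)cc2)cnc2c(C(F)(F)F)cccc12` and compound 3 `CN(C)C(=O)C[C@H](CSc1ccccc1)Nc1c(C(=O)N/N=C/c2ccc(OC(F)(F)F)cc2)cnc2c(C(F)(F)F)cccc12`. In an ADME assay on Vero cells (Chlorocebus sabaeus) for cytotoxicity, read by MTT assay, with a stated time of 72 h (a lower number here means a stronger inhibitor, a higher number a weaker inhibitor), compound 1 gives only a limit of the assay, > 62.5 ug/mL. Compound 2 likewise gives a limit, > 62.5 ug/mL. Compound 3 also gives only a limit, > 62.5 ug/mL, and so stands at the same edge of the assay as the other two. The steps between them, a step that the two limits leave unreadable from compound 1 to compound 2, a step that the two limits leave unreadable from compound 1 to compound 3 and a step that the two limits leave unreadable from compound 2 to compound 3, cannot be sized because of the limit of > 62.5 ug/mL in this assay, at which 3 of the 3 values shown sit.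

Compound 4 `CN(C)C(=O)C[C@H](CSc1ccccc1)Nc1c(C(=O)N/N=C/c2ccc(Br)s2)cnc2c(C(F)(F)F)cccc12` differs from compound 3 by 5-bromothiophen-2-yl in place of 4-(trifluoromethoxy)phenyl on a carbon with a double bond to nitrogen. Within the data shown here, none of the measured steps bears on this change in a readable way, so for compound 4 the expected outcome in this assay is again a limit, with an expected step that the limit leaves unreadable from compound 3 to compound 4. Compound 4 is therefore estimated at 90 ug/mL, within 50 ug/mL to 200 ug/mL.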

Compound 4, half-maximal inhibitory concentration: > 62.5 ug/mL
Compound 4: a limit, no number (the forecaster's own chance of this, stated with the estimate: 85%); the middle value lies beyond the limit too.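

Among these compounds, compound 4 is again only a limit, so no step from compound 1, compound 2 or compound 3 to compound 4 can be read in this assay: the limit of > 62.5 ug/mL in this assay, at which 4 of the 4 values shown sit. Left open is whether these groups on the carbon with a double bond to nitrogen differ at all in this assay.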